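From cyclopropyloxy to tert-butoxy on the shared core

The source may report more compounds than this note shows. Statements on the series, on what has been measured and on what is new or still open speak of the compounds shown alone.

Measured in an ADME assay on microsomes from liver (Homo sapiens) for metabolic stability, with a stated time of 60 min, tested at 1 uM; a lower number here means that less of the compound is left, a higher number that more of the compound is left:
- compound 1 `COc1cc(-c2cnn3cc(OC)c(-c4cnn(C)c4)nc23)ccn1` gives 43%
- compound 2 `COc1cn2ncc(-c3ccnc(OC(C)C)c3)c2nc1-c1cnn(C)c1` gives 32%
- compound 3 `COc1cn2ncc(-c3ccnc(OC4CC4)c3)c2nc1-c1cnn(C)c1` gives 47%

Compound 3 stands at 47%, which is level, within the scatter, with compound 1 at 43% and clear of compound 2 at 32%. The next structure is compound 4 `COc1cn2ncc(-c3ccnc(OC(C)(C)C)c3)c2nc1-c1cnn(C)c1`, and the change is tert-butyl in place of cyclopropyl on an oxygen on an aromatic ring.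

Three measured steps at this same oxygen bear on it. Isopropyl in place of methyl gave a number 11 percentage points lower from compound 1 to compound 2 (beyond the scatter), cyclopropyl in place of methyl gave a number 4 percentage points higher from compound 1 to compound 3 (within the scatter), and cyclopropyl in place of isopropyl gave a number 15 percentage points higher from compound 2 to compound 3 (beyond the scatter). Among the compounds with values here, no tert-butyl compound has been measured, and three compounds establish no rule. Isopropyl is the nearest measured group, so a modest step in the reverse direction of a number 15 percentage points higher from compound 2 to compound 3 (beyond the scatter) is expected.

The expected change in this assay is a number 14 percentage points lower from compound 3 to compound 4 (beyond the scatter). For compound 4 the estimate is 33%, with an expected range from 17% to 48%.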

Compound 4, percent of the compound remaining: 35%
Estimate against measurement, compound 4: 2 percentage points below; the measured number falls inside the stated range.
By their numbers in this assay, from the lowest: compounds 2, 4, 1 and 3 (each within the scatter of the next, the first and the last beyond it).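

With tert-butyl on the oxygen, this assay gave a number 12 percentage points lower from compound 3 to compound 4 (beyond the scatter), so cyclopropyl now stands clear of both open branched groups, isopropyl and tert-butyl. Adding the further methyl to the saturated chain carbon gave a number 3 percentage points higher from compound 2 to compound 4 (within the scatter), so isopropyl and tert-butyl cannot be told apart here, although methyl on the oxygen does not fit a simple grouping: a number 8 percentage points lower from compound 1 to compound 4 (within the scatter), while its step to isopropyl is beyond the scatter and its step to cyclopropyl is within it. Nothing available gives a reason for the separation of cyclopropyl from tert-butyl.

The compounds shown leave open how cyclobutyl or a longer chain such as n-propyl on this oxygen would read. They also leave open whether an amine in place of the oxygen would keep the number of compound 3, 47%.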